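The source may hold more compounds than are shown below. What is called first, only, known or untested is meant among the compounds shown, and "the series" means these compounds.

Compound 1 `CCCCCCCCCCCCCC[C@H](O)[C@H](CO[Si](c1ccccc1)(c1ccccc1)C(C)(C)C)NC(=O)OC(C)(C)C`, compound 2 `CCCCCCCCCCCCCC[C@H](OCOC)[C@H](CO[Si](c1ccccc1)(c1ccccc1)C(C)(C)C)NC(=O)OC(C)(C)C` and compound 3 `CCCCCCCCCCCCCC[C@H](OCOC)[C@H](CN(CC)CC)NC(=O)OC(C)(C)C` were examined in a functional assay on MCF7 cells (Homo sapiens) for antiproliferative activity, read by sulforhodamine B assay, with a stated time of 48 h, tested at 10 uM (on this read-out higher numbers stand for more inhibition at the one concentration tested (going by the name of the read-out) and lower numbers for less inhibition), and compound 4 `CCCCCCCCCCCCCC[C@H](O)[C@H](CN(CC)CC)NC(=O)OC(C)(C)C` remains to be measured there. In this assay compound 1 gives 2.79%, compound 2 gives -7.95% and compound 3 gives 25.3%. Compound 1 and compound 2 share a core and differ only in the change (hydrogen in place of methoxymethyl on an oxygen on a saturated carbon), which made a step of a number 10.7 percentage points higher from compound 2 to compound 1 (beyond the scatter). Compound 3 and compound 4 differ from each other by the change (hydrogen in place of methoxymethyl on an oxygen on a saturated carbon), the same change made at the same kind of place; the difference between the core of compound 3 and the core of compound 2 is not broken down here. Compound 3 already stands highest of the three measured numbers, so the open question is whether the same step carries over on its core. The step from compound 3 to compound 4 is expected to be about a number 9.7 percentage points higher from compound 3 to compound 4 (within the scatter), resting on the earlier step of a number 10.7 percentage points higher from compound 2 to compound 1 (beyond the scatter). Compound 4 is therefore estimated at 35%, with the likely range running from 20% to 50%.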

Compound 4, a percentage reported as inhibition, at one concentration (the size of the read-out at that concentration, not a potency): 18.7%
Estimate against measurement, compound 4: 16.3 percentage points above, outside the stated range (below it).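

In this assay, putting hydrogen in place of methoxymethyl on the oxygen gives a number 6.6 percentage points lower from compound 3 to compound 4 (within the scatter) and so, on this core, leaves a step that cannot be told apart from the scatter of repeated measurements. This shows that the earlier step cannot simply be carried onto the core of compound 3, although two pairs cannot show which part of the cores makes the difference or how the change would behave on a third core. The same swap gave two distinct outcomes in this series: the same change on two cores in this assay, a number 10.7 percentage points higher (beyond the scatter) from compound 2 to compound 1 and a number 6.6 percentage points lower (within the scatter) from compound 3 to compound 4, 17.3 percentage points apart, beyond the scatter of two such steps.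

The compounds shown leave open how the numbers would respond if an acetyl group stood on that oxygen instead of hydrogen or methoxymethyl. They also leave open whether a free primary amine in place of the carbamate, or a shorter chain in place of the long one, would change the reading on either core.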